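Methyl for Hydrogen on an Aromatic Oxygen, Before Measurement

The source may report more compounds than this note shows. Statements on the series, on what has been measured and on what is new or still open speak of the compounds shown alone.

Compound 1 `O=C(/C=C/c1ccc(OCCCCCO[N+](=O)[O-])c(O)c1)OCCCCCO[N+](=O)[O-]` and compound 3 `COc1cc(/C=C/C(=O)OCCCCCO[N+](=O)[O-])ccc1OCCCCCO[N+](=O)[O-]` differ by one change, (methyl in place of hydrogen on an oxygen on an aromatic ring). In a functional assay on M4E cells (Homo sapiens) for cytotoxicity, read by resazurin assay, with a stated time of 72 h (on this read-out lower numbers stand for stronger inhibition and higher numbers for weaker inhibition), compound 1 gives only a limit, > 50000 nM. In this assay compound 3 also gives only a limit, > 50000 nM. The step between them, a step that the two limits leave unreadable from compound 1 to compound 3, cannot be read because of the limit of > 50000 nM in this assay, at which 3 of the 3 values shown sit. Compound 2 `O=C(/C=C/c1ccc(OCCCCO[N+](=O)[O-])c(O)c1)OCCCCO[N+](=O)[O-]` differs from compound 1 in more than one place; the difference between the two cores is not broken down here. In this assay compound 2 gives only a limit, > 50000 nM. Compound 4 `COc1cc(/C=C/C(=O)OCCCCO[N+](=O)[O-])ccc1OCCCCO[N+](=O)[O-]` carries the same change from compound 2, (methyl in place of hydrogen on an oxygen on an aromatic ring). The expected step from compound 2 to compound 4 is a step that the limit leaves unreadable from compound 2 to compound 4, resting on compound 1 and compound 3 both sitting at the limit, (the limit of > 50000 nM in this assay, at which 3 of the 3 values shown sit). Compound 4 is therefore estimated at 80000 nM, between 40000 nM and 200000 nM, most probably reported again only as a limit.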

Compound 4, half-maximal inhibitory concentration: > 50000 nM
Compound 4: a limit, no number; the forecaster's own chance of this, stated with the estimate: 90%; the middle value does not contradict the limit.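

In this assay compound 2 and compound 4 both give only a limit, so no step can be read between them: the limit of > 50000 nM in this assay, at which 4 of the 4 values shown sit. The compounds shown leave open whether hydroxy to methoxy alters cytotoxicity at all, and how strong any of them is.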